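Replacing phenyl with (dimethylamino)methyl on the amide

The compounds below may be only part of what the source reports. "The series", "measured", "known", "first", "only" and "open" are said of these compounds alone.

Three compounds share one core: compound 1 (`COc1ccc(NC(=O)c2cccc(Nc3ncc(F)c(Nc4ccc(F)cc4)n3)c2)cc1`), compound 2 (`O=C(Nc1cccc(Nc2ncc(F)c(Nc3ccc(F)cc3)n2)c1)c1ccncc1`) and compound 3 (`O=C(Nc1cccc(Nc2ncc(F)c(Nc3ccc(F)cc3)n2)c1)c1ccccc1`). In a functional assay on KBVIN cells (Homo sapiens) for antiproliferative activity, read by sulforhodamine B assay, with a stated time of 3 days (on this read-out higher numbers stand for weaker inhibition of growth and lower numbers for stronger inhibition of growth), compound 1 gives 15700 nM and compound 2 gives 4570 nM. For compound 3 only a limit is known (> 10000 nM). Compound 4 (`CN(C)CC(=O)Nc1cccc(Nc2ncc(F)c(Nc3ccc(F)cc3)n2)c1`) carries (dimethylamino)methyl in place of phenyl on a carbonyl carbon. The closest measured change sits on that same carbonyl carbon, where phenyl replaces pyridin-4-yl (an at least 2.1-fold higher number from compound 2 to compound 3 (0.34 log units; beyond the scatter)). A broader change gives a similar picture (a 3.4-fold lower number from compound 1 to compound 2 (0.54 log units; beyond the scatter)). With compound 2 at 4570 nM as the guide, a modest step to a lower number is expected in this assay (an at least 1.6-fold lower number from compound 3 to compound 4 (0.22 log units; that floor lies within the scatter)). Compound 4 is estimated at 6000 nM (range 2000 nM to 15000 nM).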

Compound 4, concentration for 50% growth inhibition: 1810 nM
Estimate against measurement, compound 4: 3.3-fold (0.52 log units) above; the measured number lies below the stated range.
By their numbers in this assay, from the lowest: compound 4; then compound 2; then compound 1.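

In this assay, an aromatic ring on this carbonyl carbon proves unnecessary for growth inhibition: replacing pyridin-4-yl with the ringless (dimethylamino)methyl gives a 2.5-fold lower number from compound 2 to compound 4 (0.40 log units; beyond the scatter). Replacing phenyl with the same group gives an at least 5.5-fold lower number from compound 3 to compound 4 (0.74 log units; beyond the scatter), and replacing (4-methoxyphenyl)carbamoyl with (((dimethylamino)methyl)carbonyl)amino gives an 8.7-fold lower number from compound 1 to compound 4 (0.94 log units; beyond the scatter). Compound 3 is known only as a limit: the limit of > 10000 nM in this assay, at which 1 of the 4 values shown sits.

On these data alone, what remains open is whether the nitrogen of (dimethylamino)methyl matters or only the loss of the ring. A plain ethyl group, a longer chain ending in the same amine, or a morpholine ring at this carbonyl carbon would help separate these possibilities.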